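The source may hold more compounds than are shown below. What is called first, only, known or untested is meant among the compounds shown, and "the series" means these compounds.

Compound 1 `c1cncc(CN[C@H]2C3C4CC5C6C4CC3C6C52)c1` was tested in an assay on brain for displacement of a labelled ligand from Sigma non-opioid intracellular receptor 1 (Rattus norvegicus) (on this read-out higher numbers stand for weaker inhibition and lower numbers for stronger inhibition), and in that assay compound 1 gives 508 nM. Compound 3 `CN(Cc1cccnc1)[C@H]1C2C3CC4C5C3CC2C5C41` carries the change (methyl in place of hydrogen on an amine nitrogen), and in this assay compound 3 gives 970 nM. The step of a 1.9-fold higher number from compound 1 to compound 3 (0.28 log units; within the scatter) is the whole measured effect of that change, and it does not rise above the usual noise of repeated measurements. Compound 2 `Fc1cccc(CCCN[C@H]2C3C4CC5C6C4CC3C6C52)c1` differs from compound 1 in more than one place; the difference between the two cores is not broken down here. In this assay compound 2 gives 24.9 nM, the lowest number of the three, and its steps to compound 1 and to compound 3 both lie beyond the scatter. Compound 4 `CN(CCCc1cccc(F)c1)[C@H]1C2C3CC4C5C3CC2C5C41` has not yet been measured in this assay. It stands to compound 2 as compound 3 stands to compound 1: the change is methyl in place of hydrogen on an amine nitrogen, the same change at a place described in the same words. Among the measured compounds shown here, only one measured example of this change is available, so any expectation rests on it alone. Because that example gave a 1.9-fold higher number from compound 1 to compound 3 (0.28 log units; within the scatter), a step of similar and small size is expected here, namely a 1.6-fold higher number from compound 2 to compound 4 (0.21 log units; within the scatter). For compound 4 in this assay the expected value is therefore 40 nM, with a likely range from 15 nM to 110 nM.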

Compound 4, inhibition constant: 429 nM
Beside the measured number, compound 4's estimate is 11-fold (1.03 log units) below it; the whole stated range lies below it.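

In this assay, methyl in place of hydrogen on the amine nitrogen gives a 17-fold higher number from compound 2 to compound 4 (1.24 log units; beyond the scatter), so on the core of compound 2 this small change goes with much weaker inhibition. The same change therefore cannot be assumed to behave alike on different cores in this series, and a step measured on one core proved a poor guide to the step on another: the same change on two cores in this assay, a 1.9-fold higher number (0.28 log units; within the scatter) from compound 1 to compound 3 and a 17-fold higher number (1.24 log units; beyond the scatter) from compound 2 to compound 4, 9.0-fold (0.96 log units) apart, beyond the scatter of two such steps With only these two pairs, this does not show which difference between the cores matters, why the change is tolerated on one and not on the other, or whether any general rule holds, and since the step on the core of compound 1 lies within the scatter, it gives no firm direction of its own.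

The compounds shown leave open whether the large step depends on the length of the propyl chain, on the fluorine atom, or on the aromatic ring at the end of the chain, since these features all differ together between the two cores. They also leave open whether a larger group on the same nitrogen, such as ethyl, would follow the methyl on either core.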